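A few compounds are considered here, and "the series" means these few. Any claim that something is new, unique, unknown or untested is made for them only; others in the source may bear on it.

Of the compounds shown here, three built on a shared core have been tested in a functional assay on MGC-803 cells (Homo sapiens) for antiproliferative activity, read by CellTiter-Glo, with a stated time of 72 h; on this read-out lower numbers stand for stronger inhibition and higher numbers for weaker inhibition. Going by the values given here, compound 1 `COc1ccccc1-c1cc(/C=C/c2ccc(C(=O)NO)cc2)ccn1` is the one compound that returns a number: in this assay compound 1 gives 6350 nM. Compound 2 `O=C(NO)c1ccc(/C=C/c2cccc(-c3cc(F)ccc3O)c2)cc1` reaches only a limit of the assay, > 10000 nM, rather than a number. Compound 3 `Cc1ccc(-c2cc(/C=C/c3ccc(C(=O)NO)cc3)c(F)cn2)cc1` likewise stops at a limit, > 10000 nM. Among the compounds with values here, compound 1 therefore stands alone as the only measured value in the set. The other two sit at the limit of > 10000 nM in this assay, at which 2 of the 3 values shown sit. Within the data shown here, no pair of measured compounds differs in just one place, so no measured step is available.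

Compound 4 `O=C(NO)c1ccc(/C=C/c2ccncc2)cc1` has not yet been measured. It differs from compound 1 in one place hydrogen in place of 2-methoxyphenyl on an aromatic carbon: the 2-methoxyphenyl leaves and only a hydrogen enters, so compound 4 is the smaller molecule. Among the measured compounds shown here, no measured step tells what losing such a group costs or gains here, and the two limits give no direction. The expectation for the step of a 1.3-fold higher number from compound 1 to compound 4 (0.10 log units; within the scatter) is a modest move toward weaker inhibition, though not one firmly beyond the scatter. Compound 4 is estimated at 8000 nM, with a plausible range from 2500 nM to 25000 nM, and a fair chance that it too ends only at a limit.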

Compound 4, half-maximal inhibitory concentration: 3930 nM
Estimate against measurement, compound 4: 2.0-fold (0.31 log units) above, and the stated range covers the measured number.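

In this assay, going by these compounds alone, the first measured step at this position is a 1.6-fold lower number from compound 1 to compound 4 (0.21 log units; within the scatter), where hydrogen replaces the 2-methoxyphenyl group on an aromatic carbon next to the ring nitrogen. The whole group, with its six-membered aromatic ring of carbon and its oxygen, can therefore go without the number moving beyond the usual scatter of repeated measurements, so on this read-out the 2-methoxyphenyl group shows no measurable contribution at this position. Compound 2 and compound 3 end at a limit of the assay and not at a number, so steps involving them cannot be read: the limit of > 10000 nM in this assay, at which 2 of the 4 values shown sit.

The compounds shown leave open whether any other group on this carbon, such as a plain phenyl ring, an amine or a carboxylic acid, would shift the number beyond the scatter in either direction. They also leave open whether the same small difference between a large aromatic group and a hydrogen would appear at other positions of the shared core.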